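Moving the Chlorine on Two Related Cores

A few compounds are considered here, and "the series" means these few. Any claim that something is new, unique, unknown or untested is made for them only; others in the source may bear on it.

Compound 1 `O=c1[nH]cc(S(=O)(=O)Nc2ccccc2-c2cn(-c3cccc(Cl)c3)nn2)c(=O)[nH]1` gives > 100000 nM in an ADME assay on GES1 cells (Homo sapiens) for cytotoxicity, read by MTT assay, with a stated time of 24 h (a lower number here means that less compound is tolerated, a higher number that more compound is tolerated), which is a limit of the assay and not a number (the limit of > 100000 nM in this assay, at which 1 of the 3 values shown sits).
Compound 2 `O=c1[nH]cc(S(=O)(=O)Nc2ccccc2-c2cn(-c3ccc(Cl)cc3)nn2)c(=O)[nH]1` gives 26700 nM in this assay.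
Compound 3 `O=c1[nH]cc(S(=O)(=O)Nc2cccc(-c3cn(-c4cccc(Cl)c4)nn3)c2)c(=O)[nH]1` gives 26200 nM in this assay.

The change 4-chlorophenyl in place of 3-chlorophenyl on an aromatic nitrogen gave an at least 3.7-fold lower number from compound 1 to compound 2 (0.57 log units; beyond the scatter). The difference between the core of compound 1 and the core of compound 3 is not broken down here. Compound 4 `O=c1[nH]cc(S(=O)(=O)Nc2cccc(-c3cn(-c4ccc(Cl)cc4)nn3)c2)c(=O)[nH]1` carries the same change, (4-chlorophenyl in place of 3-chlorophenyl on an aromatic nitrogen), on the core of compound 3, and the two values of compound 2 and compound 3 lie within the scatter of each other. For compound 4, a smaller step than the earlier one is expected, because compound 3 already gives 26200 nM. The expected step is a 2.0-fold lower number from compound 3 to compound 4 (0.30 log units; within the scatter). Compound 4 is therefore estimated at 13000 nM, between 4500 nM and 35000 nM.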

Compound 4, half-maximal cytotoxic concentration: 11300 nM
Compound 4: middle estimate off by 1.2-fold (0.06 log units), on the high side, and the stated range covers the measured number.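

On the core of compound 3, 4-chlorophenyl in place of 3-chlorophenyl gave a 2.3-fold lower number from compound 3 to compound 4 (0.37 log units; beyond the scatter) in this assay, meaning that less of the compound with 4-chlorophenyl is tolerated. Compound 1 gives > 100000 nM, which is a limit of the assay and not a number. The change therefore lowers the number on both cores shown, but this does not show that the step keeps its size from one core to the other: the same change on two cores in this assay, an at least 3.7-fold lower number (0.57 log units; beyond the scatter) from compound 1 to compound 2 and a 2.3-fold lower number (0.37 log units; beyond the scatter) from compound 3 to compound 4; the limit leaves it open whether they differ.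

Two cores are too few to show whether the change would act the same way on a third. From the compounds shown here alone, how an amine or a carboxylic acid in place of the chlorine would read in this assay also stays open.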